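This account rests on a few compounds, and the source may have more. Where it says the series, first, only, none or still open, it means among the compounds named here.

Measured compounds:
- compound 1, `Fc1ccc(-c2nc3cc(C(F)(F)F)ccc3[nH]2)cc1`: 60000 nM
- compound 2, `O=[N+]([O-])c1ccc(-c2nc3cc(Cl)c(Cl)cc3[nH]2)cc1`: >= 100000 nM
- compound 3, `O=C(CN1CCN(c2ccccc2)CC1)Nc1ccc(-c2nc3cc(C(F)(F)F)ccc3[nH]2)cc1`: > 100000 nM

Among the measured compounds shown here, in an ADME assay on Vero cells (Chlorocebus sabaeus) for cytotoxicity (a lower number here means that less compound is tolerated, a higher number that more compound is tolerated), compound 1 gives 60000 nM, the only number among the three values shown. Compound 2 reaches a limit of this assay, >= 100000 nM, and not a number; the limit of >= 100000 nM in this assay, at which 1 of the 3 values shown sits, marks it. Compound 3 likewise sits at a limit of this assay, > 100000 nM, which the limit of > 100000 nM in this assay, at which 1 of the 3 values shown sits, records. Compound 4, `O=C(O)CCC(=O)Nc1ccc(-c2nc3cc(C(F)(F)F)ccc3[nH]2)cc1`, has not yet been measured in this assay. It is obtained from compound 1 by the change (((2-carboxyethyl)carbonyl)amino in place of fluoro on an aromatic carbon). For the measured compounds named here, no step between measured compounds shares this change, so there is no measured step to lean on; the ((2-carboxyethyl)carbonyl)amino group enters where compound 3 also carries a large amino-linked group, and compound 3 gives only a limit of this assay. The step of a 1.7-fold higher number from compound 1 to compound 4 (0.22 log units; within the scatter) is therefore expected to be upward, beyond the scatter, toward more compound tolerated. For compound 4 the expected value in this assay is 100000 nM, within a range from 50000 nM to 200000 nM, with a fair chance that only a limit is reported.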

Compound 4, half-maximal cytotoxic concentration: > 100000 nM
Compound 4 gave a limit, no number; the forecaster's own chance of this, stated with the estimate: 60%; the middle value lies on the limit itself.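

In this assay compound 4 gives > 100000 nM, which is a limit of the assay and not a number. Putting ((2-carboxyethyl)carbonyl)amino in place of fluoro on this aromatic carbon, para to a large group, gives an at least 1.6-fold higher number from compound 1 to compound 4 (0.22 log units; that floor lies within the scatter), so this larger chain brings no fall in the number, though the true size of the step stays unread. Compound 4 is now the second compound, after compound 3, with a large amino-linked group at this place to sit at the same limit: the limit of > 100000 nM in this assay, at which 2 of the 4 values shown sit.

The compounds shown leave open whether a plain amine or a shorter amide such as an acetamide on that carbon would also reach this limit. They also leave open how far beyond the limit compound 3 and compound 4 lie.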